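Carrying One Substitution From One Core to Its Isomer

A few compounds are considered here, and "the series" means these few. Any claim that something is new, unique, unknown or untested is made for them only; others in the source may bear on it.

Three compounds were tested in a functional assay on HT-1080 cells (Homo sapiens) for cytotoxicity, read by MTT assay, with a stated time of 72 h; a lower number here means a stronger inhibitor, a higher number a weaker inhibitor. Compound 1 `COc1ccc(Cn2cc3cc(C(=N)Nc4ccc(N5CCN(C)CC5)cc4)ncc3n2)cc1` gives 3200 nM. Compound 2 `CN1CCN(c2ccc(NC(=N)c3cc4cn(C)nc4cn3)cc2)CC1` gives 21000 nM, and compound 3 `CN1CCN(c2ccc(NC(=N)c3cc4cnn(C)c4cn3)cc2)CC1` gives 24000 nM. Compound 4 `COc1ccc(Cn2ncc3cc(C(=N)Nc4ccc(N5CCN(C)CC5)cc4)ncc32)cc1` has not yet been measured in this assay.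

Compound 2 and compound 1 differ in a single place: 4-methoxyphenyl in place of hydrogen on a saturated chain carbon bound to an aromatic nitrogen. This change produced a 6.6-fold lower number from compound 2 to compound 1 (0.82 log units; beyond the scatter).

Compound 3 is built from the same atoms as compound 2, joined differently; the difference between the two cores is not broken down here. In this assay the values of compound 2 and compound 3 lie within the scatter of each other, so no order between them can be stated.

Compound 4 stands to compound 3 exactly as compound 1 stands to compound 2: 4-methoxyphenyl in place of hydrogen on a saturated chain carbon bound to an aromatic nitrogen. The place is described in the same words in both pairs, so this is the same change made on the other core. The step from compound 3 to compound 4 is expected to be a 6.0-fold lower number from compound 3 to compound 4 (0.78 log units; beyond the scatter), because the identical change once gave a 6.6-fold lower number from compound 2 to compound 1 (0.82 log units; beyond the scatter). Whether the second core carries the change as well as the first is not known from the data, which is why the range given is wide. Compound 4 is estimated at 4000 nM, with a range from 1500 nM to 12000 nM.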

Compound 4, half-maximal inhibitory concentration: 5300 nM
For compound 4 the middle estimate is 1.3-fold (0.12 log units) below the measured one; the range from low to high includes it.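

In this assay, replacing methyl with 4-methoxybenzyl on the second core gave a 4.5-fold lower number from compound 3 to compound 4 (0.66 log units; beyond the scatter), so the change that had lowered the number on the first core also lowered it on its isomer. Set side by side, the two steps cannot be told apart in size: the same change on two cores in this assay, a 6.6-fold lower number (0.82 log units; beyond the scatter) from compound 2 to compound 1 and a 4.5-fold lower number (0.66 log units; beyond the scatter) from compound 3 to compound 4, 1.4-fold (0.16 log units) apart, within the scatter of two such steps. For the compounds shown here, this shows that, in this one cell assay, the change carried from one core to the other with its size intact, but it rests on only two pairs and does not show that the same would hold on any further core, nor does it explain why the step is of this size.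

The compounds shown leave open which part of the 4-methoxybenzyl group matters, since the only groups compared at this place are methyl and 4-methoxybenzyl, and a plain benzyl, a longer chain such as butyl or a benzyl carrying a carboxylic acid would each test this. They also leave open whether the agreement between the cores would survive a change elsewhere in the molecule, for example replacing the methyl on the piperazine with an acetyl group.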